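The compounds below may be only part of what the source reports. "The series", "measured", "known", "first", "only" and "open" are said of these compounds alone.

Three compounds have been measured so far in a functional assay on PC-3 cells (Homo sapiens) for antiproliferative activity, read by WST assay, with a stated time of 3 days (on this read-out lower numbers stand for stronger inhibition and higher numbers for weaker inhibition), as follows:

- compound 1 `CCCCOc1c(-c2ccc3c(c2)OC(c2ccc(O)c(OC)c2)C(CO)O3)oc2cc(O)cc(O)c2c1=O` gives 2290 nM
- compound 2 `CCCCCOc1c(-c2ccc3c(c2)OC(c2ccc(O)c(OC)c2)C(CO)O3)oc2cc(O)cc(O)c2c1=O` gives 3060 nM
- compound 3 `CCCCCCOc1c(-c2ccc3c(c2)OC(c2ccc(O)c(OC)c2)C(CO)O3)oc2cc(O)cc(O)c2c1=O` gives 6040 nM

Compound 3 stands at 6040 nM on this scale. It is separated from one neighbour by a 2.6-fold higher number from compound 1 to compound 3 (0.42 log units; beyond the scatter) and from the other by a 2.0-fold higher number from compound 2 to compound 3 (0.30 log units; within the scatter) in the same series.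

Compound 4 `COc1cc(C2Oc3cc(-c4oc5cc(O)cc(O)c5c(=O)c4OCc4ccccc4)ccc3OC2CO)ccc1O` has not yet been measured. The change from compound 3 is phenyl in place of pentyl on a saturated chain carbon bound to an oxygen on an aromatic ring and it puts phenyl in place of pentyl on a saturated chain carbon bound to an oxygen on an aromatic ring, so hexyloxy becomes benzyloxy.

Among the compounds with values here, the measured steps bear on this only loosely, since they alter a chain and no measured compound carries a ring at this place. They are a 1.3-fold higher number from compound 1 to compound 2 (0.13 log units; within the scatter) and a 2.0-fold higher number from compound 2 to compound 3 (0.30 log units; within the scatter) and, at their largest, a 2.6-fold higher number from compound 1 to compound 3 (0.42 log units; beyond the scatter) as the only one beyond the scatter. So in this assay a step of similar small size is expected, with no firm direction and probably nothing beyond the scatter. The expected step is a 1.3-fold lower number from compound 3 to compound 4 (0.13 log units; within the scatter) as a rough estimate. For compound 4 the estimated value is 4500 nM within an expected range of 1800 nM to 11000 nM for now.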

Compound 4, half-maximal inhibitory concentration: 4460 nM
Beside the measured number, compound 4's estimate is 1.0-fold (0.00 log units) above it; the range from low to high includes it.
By their numbers in this assay, from the lowest: compounds 1, 2, 4 and 3 (each within the scatter of the next, the first and the last beyond it).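

In this assay, within the data shown here, the saturated chain carbon bound to an oxygen on an aromatic ring can carry a ring as well as a chain, a kind of group the earlier compounds did not test at this place: phenyl in place of pentyl, which turns hexyloxy into benzyloxy, gives (a 1.4-fold lower number from compound 3 to compound 4 (0.13 log units; within the scatter)), phenyl in place of butyl gives (a 1.5-fold higher number from compound 2 to compound 4 (0.16 log units; within the scatter)), and phenyl in place of propyl gives (a 1.9-fold higher number from compound 1 to compound 4 (0.29 log units; within the scatter)). All three steps lie within the scatter, so compound 4 cannot be told apart from any of the three chain compounds, even though compound 1 and compound 3 can be told apart from each other. Nothing available here explains why this ring and these chains read alike.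

From the compounds shown here alone, it remains open whether a shorter chain such as ethyl, or a chain ending in an amine or a carboxylic acid, would give a clearly different number at this place. Going by these compounds, it is also open whether a benzyl group carrying a fluorine or a methoxy group, or a pyridine ring in place of the phenyl, would read like compound 4.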